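The source may report more compounds than this note shows. Statements on the series, on what has been measured and on what is new or still open speak of the compounds shown alone.

Working notes on the thiazole acetic acid series. Compound 3 `O=C(O)Cc1sc(C(c2ccc(F)cc2)c2ccc(F)cc2)nc1-c1cc(F)cc(F)c1` gives 340 nM in an in vitro functional assay on HEK285-7 cells for antagonist activity at prostaglandin D2 receptor 2 (Homo sapiens), read by BRET and beta-arrestin recruitment; on this read-out higher numbers stand for weaker inhibition and lower numbers for stronger inhibition. For comparison, compound 1 `O=C(O)Cc1sc(CSc2ccccc2)nc1-c1ccc(Cl)cc1` gives 450 nM, and compound 2 `O=C(O)Cc1sc(C(c2ccc(F)cc2)c2ccc(F)cc2)nc1-c1ccc(Cl)cc1` gives 180 nM; compound 3 lies within the scatter of both of these, so no ranking among the three is supported by the numbers. Among the measured compounds shown here, the only single-point step available is a 1.9-fold higher number from compound 2 to compound 3 (0.28 log units; within the scatter), which amounts to no change beyond the scatter on swapping the aryl group at this position of the core. Compound 4 `N#Cc1cc(-c2nc(C(c3ccc(F)cc3)c3ccc(F)cc3)sc2CC(=O)O)ccc1F` varies the same position again: 3-cyano-4-fluorophenyl in place of 3,5-difluorophenyl on an aromatic carbon. For the measured compounds named here, no measured step addresses a nitrile on this aryl group, and no other pair of compounds isolates this change, so the expectation rests solely on the observation that the aryl swap measured so far stayed within the scatter. Compound 4 is therefore expected to come in near 300 nM in this assay, with a range of 100 nM to 900 nM. This estimate corresponds to an expected step of a 1.1-fold lower number from compound 3 to compound 4 (0.05 log units; within the scatter), that is, nothing resolvable beyond the scatter, while remaining open to a modest shift in either direction.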

Compound 4, half-maximal inhibitory concentration: 520 nM
Estimate against measurement, compound 4: 1.7-fold (0.24 log units) below; low and high end bracket the measured number.
By their numbers in this assay, from the lowest: compounds 2, 3, 1 and 4 (each within the scatter of the next, the first and the last beyond it).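

In this assay, putting 3-cyano-4-fluorophenyl in place of 3,5-difluorophenyl gives a 1.5-fold higher number from compound 3 to compound 4 (0.18 log units; within the scatter), so a nitrile on this aryl group, with its hydrogen-bond acceptor, cannot be told apart from the difluoro pattern at this position. Against 4-chlorophenyl, the same group gives a 2.9-fold higher number from compound 2 to compound 4 (0.46 log units; beyond the scatter), the first step at this position to clear the scatter, which shows that the choice of aryl group here can register in this read-out, though only modestly. Nothing at hand accounts for this step.

Still open, from the compounds shown here alone, is whether the nitrile or the ring fluorine carries the step from 4-chlorophenyl, which a plain 3-cyanophenyl group would separate. Also open, going by these compounds, is how this position responds to an aryl group bearing an amine, a methoxy group or a carboxylic acid.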